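The compounds below may be only part of what the source reports. "The series", "measured", "known", "first", "only" and "open" are said of these compounds alone.

In an ADME assay on the whole organism for pharmacokinetics, with Rattus norvegicus as the target (on this read-out higher numbers stand for fast clearance and lower numbers for slow clearance), the three measured compounds stand as follows:

Compound 1, `Cc1cnc(NC(=O)[C@H](COC(C)C)Oc2ncnc3c2cnn3-c2ccccc2Cl)cn1`, gives 61 mL/min/kg.
Compound 2, `Cc1ccc(NC(=O)[C@H](COC(C)C)Oc2ncnc3c2cnn3-c2ccccc2Cl)nc1`, gives 71 mL/min/kg.
Compound 3, `COC[C@H](Oc1ncnc2c1cnn2-c1ncccc1Cl)C(=O)Nc1cnc(C)cn1`, gives 4 mL/min/kg.

Compounds 1 and 2 share one core and differ in a single place: 5-methylpyridin-2-yl in place of 5-methylpyrazin-2-yl on an amide-type nitrogen. This change gives a 1.2-fold higher number from compound 1 to compound 2 (0.07 log units; within the scatter), so the two numbers cannot be told apart by this measurement.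

Compound 3 is built on a different core, and the difference between the two cores is not broken down here. What is clear is that compound 3 has the lowest number of the three, and its gaps to compound 1 and to compound 2 are both beyond the scatter.

Compound 4, `COC[C@H](Oc1ncnc2c1cnn2-c1ncccc1Cl)C(=O)Nc1ccc(C)cn1`, has not yet been measured. It stands to compound 3 exactly as compound 2 stands to compound 1: 5-methylpyridin-2-yl in place of 5-methylpyrazin-2-yl on an amide-type nitrogen. The place of the change is the same in both pairs, so this is the same change on a different core.

Since the same change between compound 1 and compound 2 moved the number by only a 1.2-fold higher number from compound 1 to compound 2 (0.07 log units; within the scatter), the step from compound 3 to compound 4 is expected to be small as well, about a 1.3-fold higher number from compound 3 to compound 4 (0.10 log units; within the scatter). On this basis compound 4 is expected to give roughly 5 mL/min/kg in this assay, most likely between 2.5 mL/min/kg and 10 mL/min/kg, because compound 3 gives 4 mL/min/kg and the change is expected to leave that number nearly unchanged.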

Compound 4, clearance in the Rattus norvegicus assay: 9.3 mL/min/kg
Compound 4: middle estimate off by 1.9-fold (0.27 log units), on the low side; measured number inside the range.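

In the Rattus norvegicus assay, putting 5-methylpyridin-2-yl in place of 5-methylpyrazin-2-yl on an amide-type nitrogen gives a 2.3-fold higher number from compound 3 to compound 4 (0.37 log units; beyond the scatter), a step that lies beyond the scatter, while on the other core the same change gave a 1.2-fold higher number from compound 1 to compound 2 (0.07 log units; within the scatter), a step that lies within it. Even so, the two steps cannot be told apart, so as far as these two pairs can show, the change carries over from one core to the other: the same change on two cores in the Rattus norvegicus assay, a 1.2-fold higher number (0.07 log units; within the scatter) from compound 1 to compound 2 and a 2.3-fold higher number (0.37 log units; beyond the scatter) from compound 3 to compound 4, 2.0-fold (0.30 log units) apart, within the scatter of two such steps In a physicochemical assay for lipophilicity (a lower number here means a more polar compound, a higher number a more lipophilic compound), compound 3 gives 1.4 and compound 4 gives 2.3, and this shift may go with the higher clearance, but a single pair cannot show that it is the cause, and two cores cannot show that the step would hold on every core in the series: the measured distribution coefficient of compound 3, 1.4, and of compound 4, 2.3, a number 0.90 log units higher (beyond the scatter)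

The compounds shown leave open what a plain phenyl ring carrying a methyl group would do on the same amide-type nitrogen, and whether an amine or a carboxylic acid in place of that methyl group would move either number. They also leave open which of the differences between the core of compound 1 and the core of compound 3 goes with the large gap in clearance.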